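Benzyloxy for Chloro on the Flavone Aryl Ring

A few compounds are considered here, and "the series" means these few. Any claim that something is new, unique, unknown or untested is made for them only; others in the source may bear on it.

Measured compounds:
compound 1 `O=c1cc(-c2cccc(O)c2)oc2cc(OCCCCCCCCN3CCCC3)ccc12` 43.9%
compound 2 `O=c1cc(-c2ccc(Cl)cc2)oc2cc(OCCCCCCCCN3CCCC3)ccc12` 25.7%

In an ADME assay on HepG2 cells (Homo sapiens) for cytotoxicity, read by MTT assay, with a stated time of 48 h, tested at 10 uM (on this read-out higher numbers stand for a stronger effect at the one concentration tested and lower numbers for a weaker effect), compound 2 gives the lower of the two numbers, with compound 1 standing above it by a number 18.2 percentage points lower from compound 1 to compound 2 (beyond the scatter). Compound 3 `O=c1cc(-c2ccc(OCc3ccccc3)cc2)oc2cc(OCCCCCCCCN3CCCC3)ccc12` differs from compound 2 by benzyloxy in place of chloro on an aromatic carbon. Going by the values given here, the only measured step concerns a different exchange, hydroxyl for chloro, and no step covers benzyloxy. With nothing closer to rest on, compound 3 is expected to stay near compound 2, a shift of a number 4.3 percentage points higher from compound 2 to compound 3 (within the scatter) within the scatter. The estimate for compound 3 is 30%, between 12% and 52%.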

Compound 3, a percentage reported as inhibition, at one concentration (the size of the read-out at that concentration, not a potency): 54.3%
Estimate against measurement, compound 3: 24.3 percentage points below; the measured number lies above the stated range.
By their numbers in this assay, from the lowest: compound 2; then compound 1; then compound 3.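

In this assay, going by these compounds alone, the aromatic carbon para to a large group proves responsive to what it carries: benzyloxy in place of chloro gives a number 28.6 percentage points higher from compound 2 to compound 3 (beyond the scatter), a change the earlier compounds did not cover. A substituent bearing a six-membered aromatic ring is therefore compatible with a stronger effect at the one concentration tested. No measurement at hand accounts for this rise.

On these data alone, whether the benzyloxy oxygen or its aromatic ring carries the step remains open; methoxy or phenyl at that carbon would separate the two. As far as these compounds go, how an amine there would read also remains open.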